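From a Hydroxypiperidine to an Ethylurea

The source may hold more compounds than are shown below. What is called first, only, known or untested is meant among the compounds shown, and "the series" means these compounds.

Of the compounds shown here, three sharing one core have been measured in a physicochemical assay for lipophilicity, read by HPLC, measured as octanol-water partition; on this read-out higher numbers stand for higher lipophilicity and lower numbers for lower lipophilicity. Compound 1 `O=C1O[C@@H](CN2CCC(O)CC2)CN1c1ccc(-n2cc(-c3ccccn3)cn2)c(F)c1` gives 1.63. Compound 2 `O=C(OC[C@H]1CN(c2ccc(-n3cc(-c4ccccn4)cn3)c(F)c2)C(=O)O1)c1ccccc1` gives 4.21, and compound 3 `O=CNC[C@H]1CN(c2ccc(-n3cc(-c4ccccn4)cn3)c(F)c2)C(=O)O1` gives 1.19. Compound 1 therefore stands second highest of the three: compound 3 lies nearest to it, and compound 2 lies furthest away.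

The new compound 4 `CCNC(=O)NC[C@H]1CN(c2ccc(-n3cc(-c4ccccn4)cn3)c(F)c2)C(=O)O1` differs from compound 1 in one place: (ethylcarbamoyl)amino in place of 4-hydroxypiperidin-1-yl on a saturated chain carbon bound to a saturated ring carbon. The entering group, a chain without a ring, resembles the formylamino group of compound 3 more than the benzoyloxy group of compound 2. The step of a number 0.44 log units lower from compound 1 to compound 3 (beyond the scatter) is the one that bears most directly on this change, while the step of a number 2.58 log units higher from compound 1 to compound 2 (beyond the scatter) shows how far a different kind of replacement can move the read-out.

A modest fall in this assay is therefore expected, about a number 0.28 log units lower from compound 1 to compound 4 (within the scatter). Compound 4 is estimated at 1.35, within a range from 0.85 to 1.85.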

Compound 4, partition coefficient: 2.45
For compound 4 the middle estimate is 1.10 log units below the measured one; the whole stated range lies below it.
By their numbers in this assay, from the lowest: compound 3; then compound 1; then compound 4; then compound 2.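

In this assay the step of a number 0.82 log units higher from compound 1 to compound 4 (beyond the scatter) shows that an entering group without a ring can raise the number at this position, although formylamino, also without a ring, lowered it. The two chains are thus far from interchangeable here: ethylamino in place of hydrogen on the carbonyl carbon gives a number 1.26 log units higher from compound 3 to compound 4 (beyond the scatter) and by itself turns a fall from compound 1 into a rise. The step of a number 1.76 log units lower from compound 2 to compound 4 (beyond the scatter) still leaves benzoyloxy with the highest number of the four groups.

From the compounds shown here alone, whether propylamino or butylamino in place of ethylamino on the carbonyl carbon would carry the number further up, or a plain piperidin-1-yl would sit elsewhere, stays open. No measurement among those shown accounts for these differences.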